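Working notes: hydrogen in place of chloro on compound 3

The source may report more compounds than this note shows. Statements on the series, on what has been measured and on what is new or still open speak of the compounds shown alone.

Values in an ADME assay on MT4 cells (Homo sapiens) for cytotoxicity; on this read-out higher numbers stand for lower toxicity in this test and lower numbers for higher toxicity in this test:
- compound 1 `O=[N+]([O-])c1ccc(NC(=S)Nc2cccc(C(F)(F)F)c2)cc1`: 9200 nM
- compound 2 `N#Cc1ccc(NC(=S)Nc2cccc(C(F)(F)F)c2)cc1`: 7000 nM
- compound 3 `Fc1ccc(NC(=S)Nc2cccc(C(F)(F)F)c2)cc1Cl`: 8000 nM

In this assay compound 3 stands at 8000 nM, within the scatter of both compound 1 and compound 2, so the three numbers form a single group with no order among them.

The next entry is compound 4 `Fc1ccc(NC(=S)Nc2cccc(C(F)(F)F)c2)cc1`, reached from compound 3 by this change: hydrogen in place of chloro on an aromatic carbon. In words, hydrogen in place of chloro on an aromatic carbon, ortho to a fluoro group.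

Going by the values given here, no measured step covers this exchange. Among the compounds with values here, the only step available is a 1.3-fold lower number from compound 1 to compound 2 (0.12 log units; within the scatter), cyano in place of nitro on an aromatic carbon, which is a different exchange and so bears on this one only indirectly. That step stays within the scatter, and the gaps around compound 3 do too. These three compounds therefore give no sign of a large shift on this read-out, though three compounds cannot establish a rule. No step beyond the scatter is expected in either direction.

The expected step is a 1.1-fold higher number from compound 3 to compound 4 (0.05 log units; within the scatter), an estimate that stays within the scatter. In this assay the estimated value for compound 4 is 9000 nM, with an expected range from 4500 nM to 20000 nM.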

Compound 4, half-maximal cytotoxic concentration: 31000 nM
The estimate for compound 4 lay 3.4-fold (0.54 log units) below the measured number; measured number above the stated range.
By their numbers in this assay, from the lowest: compounds 2, 3 and 1 (each within the scatter of the next); then compound 4.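

In this assay, going by these compounds alone, the carbon ortho to a fluoro group turns out not to be silent: hydrogen in place of chloro gives the first step that lies beyond the scatter (a 3.9-fold higher number from compound 3 to compound 4 (0.59 log units; beyond the scatter)), whereas the only earlier step, cyano in place of nitro, stayed within it. Within the data shown here, compound 4, with fluoro as its only group on that ring, also stands apart from the two compounds that carry a nitro or a cyano group in its place (a 3.4-fold higher number from compound 1 to compound 4 (0.53 log units; beyond the scatter); a 4.4-fold higher number from compound 2 to compound 4 (0.65 log units; beyond the scatter)), so three different one-place comparisons all end with a higher number at compound 4. Nothing measured here accounts for this shift.

As far as these compounds go, it remains open whether a bromo, methyl or methoxy group on the carbon that held chloro would stay with compound 3 or move towards compound 4, which would show whether the step belongs to chloro itself or to any group at that place. From the compounds shown here alone, it is also open whether the same exchange gives a similar step without the fluoro group, since it is seen here only ortho to that group and in this one pair.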